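A Phenyl Group in Place of 6-Methoxypyridin-3-yl

The source may report more compounds than this note shows. Statements on the series, on what has been measured and on what is new or still open speak of the compounds shown alone.

Of the compounds shown here, three sharing one core have been measured in a physicochemical assay for solubility, at pH 2; a higher number here means a more soluble compound, a lower number a less soluble compound. Compound 1 `CNc1nc(NCCCN(C)C)c2sc(-c3ccc(N)cc3)cc2n1` gives > 100 ug/mL, which is a limit of the assay. Compound 2 `CNc1nc(NCCCN(C)C)c2sc(-c3ccc(OC)nc3)cc2n1` gives > 100 ug/mL, which is also a limit. Compound 3 `CNc1nc(NCCCN(C)C)c2sc(-c3ccc(C(F)(F)F)cc3Cl)cc2n1` gives > 100 ug/mL, again a limit. Compound 2 therefore has no exact number, and the whole set amounts to the limit of > 100 ug/mL in this assay, at which 3 of the 3 values shown sit.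

Compound 4 `CNc1nc(NCCCN(C)C)c2sc(-c3ccccc3)cc2n1` has not yet been measured. It carries phenyl in place of 6-methoxypyridin-3-yl on an aromatic carbon, next to the ring sulfur: phenyl in place of 6-methoxypyridin-3-yl on an aromatic carbon. Within the data shown here, the one measured step at this place is a step that the two limits leave unreadable from compound 1 to compound 2, and it offers no size to carry over. With only limits to go on, no step beyond the usual scatter is expected in this assay, and no direction can be assigned. The expected change is a step that the limit leaves unreadable from compound 2 to compound 4. Compound 4 is estimated at 110 ug/mL, with an expected range from 60 ug/mL to 200 ug/mL.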

Compound 4, solubility: > 100 ug/mL
Compound 4: no number, only a limit; the forecaster's own chance of this, stated with the estimate: 85%; the middle value is on the limit's open side.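

In this assay compound 4 gives > 100 ug/mL, which is a limit of the assay, so the steps to compound 4 from compound 1 and from compound 2 cannot be read. The compounds shown leave open how their solubilities compare, as all rest on one limit: the limit of > 100 ug/mL in this assay, at which 4 of the 4 values shown sit.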